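Removing a Trifluoromethyl Group: From Compound 2 to Compound 4

The source may hold more compounds than are shown below. What is called first, only, known or untested is meant among the compounds shown, and "the series" means these compounds.

Of the compounds shown here, three sharing one core have been tested in a functional assay on DU-145 cells (Homo sapiens) for antiproliferative activity, read by MTT assay, with a stated time of 72 h; on this read-out higher numbers stand for weaker inhibition and lower numbers for stronger inhibition. Compound 1 `O=[N+]([O-])c1ccc(COc2ccc(Nc3ncnc4cc5c(cc34)OCCOCCO5)cc2)cc1` reaches only the limit of the assay, > 100000 nM. Compound 3 `c1ccc(COc2ccccc2Nc2ncnc3cc4c(cc23)OCCOCCO4)cc1` likewise gives a limit, > 100000 nM. Among the measured compounds shown here, compound 2 `FC(F)(F)c1ccc(COc2cccc(Nc3ncnc4cc5c(cc34)OCCOCCOCCO5)c2)cc1` is the single compound with a number in this assay, 2760 nM, and so stands alone, the other two resting at the limit of > 100000 nM in this assay, at which 2 of the 3 values shown sit. Compound 4 `c1ccc(COc2cccc(Nc3ncnc4cc5c(cc34)OCCOCCOCCO5)c2)cc1` has not been measured; it differs from compound 2 by hydrogen in place of trifluoromethyl on an aromatic carbon. For the measured compounds named here, no measured step of this kind is available, so the writer expects a modest loss of potency from compound 2 to compound 4, a 2.2-fold higher number from compound 2 to compound 4 (0.34 log units; beyond the scatter), though a change beyond the scatter is not certain. Compound 4 is accordingly estimated at 6000 nM, within 1500 nM to 30000 nM.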

Compound 4, half-maximal inhibitory concentration: > 100000 nM
Compound 4: a limit, no number (the forecaster's own chance of this, stated with the estimate: 20%); at least 16-fold (1.22 log units) between middle value and limit.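

In this assay, the trifluoromethyl group on this aromatic carbon proves decisive for compound 2 having a number at all, since hydrogen in its place gives an at least 36-fold higher number from compound 2 to compound 4 (1.55 log units; beyond the scatter). Compound 4 gives only a limit, > 100000 nM, so the step sets a minimum size and not an exact one. Among the compounds shown here, the earlier compounds offered no pair differing in one place, and compound 2 now stands as the only compound with a number: the limit of > 100000 nM in this assay, at which 3 of the 4 values shown sit. Going by these compounds, whether a chlorine atom, a methoxy group or a nitrile at this position would also give a number remains open.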